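Swapping a Nitrile for a Methyl on the Pendant Ring

The source may hold more compounds than are shown below. What is called first, only, known or untested is meant among the compounds shown, and "the series" means these compounds.

Compound 1 `O=C(O)c1ccccc1-c1ccc(CCc2ncc(-c3ccccc3)[nH]2)cc1`: 872 nM
Compound 2 `O=C(O)c1ccccc1-c1ccc(CCc2ncc(CC3CCCCC3)[nH]2)cc1`: 7.3 nM
Compound 3 `N#Cc1ccccc1Cc1cnc(CCc2ccc(-c3ccccc3C(=O)O)cc2)[nH]1`: 642 nM

Of the compounds shown here, three built on one shared core have been measured in an in vitro functional assay on cells for agonist activity at Bombesin receptor subtype-3 (Mus musculus), read by luminescence and calcium flux; on this read-out lower numbers stand for an effect already at smaller amounts and higher numbers for an effect only at larger amounts of compound. Compound 3 stands second highest of the three numbers; in this assay compound 3 gives 642 nM, which lies within the scatter of compound 1, since a 1.4-fold lower number from compound 1 to compound 3 (0.13 log units; within the scatter). Compound 2 sits far apart, as an 88-fold higher number from compound 2 to compound 3 (1.94 log units; beyond the scatter) shows, and likewise a 120-fold lower number from compound 1 to compound 2 (2.08 log units; beyond the scatter).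

Compound 4 `Cc1ccc(Cc2cnc(CCc3ccc(-c4ccccc4C(=O)O)cc3)[nH]2)cc1` has not yet been measured. It differs from compound 3 in one place: 4-methylphenyl in place of 2-cyanophenyl on a saturated chain carbon bound to an aromatic carbon.

Among the compounds with values here, two measured steps bear on this change. The step of a 1.4-fold lower number from compound 1 to compound 3 (0.13 log units; within the scatter) shows that putting a 2-cyanobenzyl in place of phenyl left the number essentially where it was, so the nitrile itself carried little weight. The step of an 88-fold higher number from compound 2 to compound 3 (1.94 log units; beyond the scatter) shows that a saturated cyclohexyl on that chain carbon gave a much lower number than a 2-cyanophenyl, but compound 4 keeps a six-membered aromatic ring of carbon only, so that large step is not expected to repeat. For compound 4 the expected step is therefore a 1.8-fold lower number from compound 3 to compound 4 (0.26 log units; within the scatter), modest at most. Compound 4 is estimated at 350 nM, with a range from 70 nM to 1800 nM.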

Compound 4, half-maximal effective concentration: 162 nM
Compound 4: middle estimate off by 2.2-fold (0.33 log units), on the high side; measured number inside the range.
By their numbers in this assay, from the lowest: compound 2; then compound 4; then compounds 3 and 1 (each within the scatter of the next).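

In this assay the exchange at this saturated chain carbon gives a 4.0-fold lower number from compound 3 to compound 4 (0.60 log units; beyond the scatter) and so reaches beyond the scatter, which shows that the number here responds to what the aromatic ring carries, even though 2-cyanophenyl and 4-methylphenyl each hold one six-membered aromatic ring of carbon only. The cyclohexyl of compound 2 still stands well apart, with a 22-fold higher number from compound 2 to compound 4 (1.35 log units; beyond the scatter) as a large step, so the 4-methylphenyl closes only part of the gap left by 2-cyanophenyl. Measured against the phenyl directly on the aromatic carbon, 4-methylbenzyl gives a 5.4-fold lower number from compound 1 to compound 4 (0.73 log units; beyond the scatter) and thus a step beyond the scatter, which 2-cyanobenzyl did not produce. Nothing at hand accounts for any of these steps.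

The two groups differ both in the substituent and in where it sits on the ring, so the compounds shown do not separate the loss of the nitrile from the arrival of the methyl. Nor do they tell where a plain benzyl or a 4-cyanobenzyl would fall, or whether an amine on this ring would keep the lower number.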